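This account rests on a few compounds, and the source may have more. Where it says the series, first, only, none or still open, it means among the compounds named here.

Compound 1 `CCN1CCN(c2cc(C)c3cc(NC(=O)c4ccc(Cl)cc4)ccc3n2)CC1` gives 1530 nM in a functional assay on MCF7 cells (Homo sapiens) for antiproliferative activity, read by MTT assay, with a stated time of 72 h; on this read-out lower numbers stand for stronger inhibition and higher numbers for weaker inhibition. Compound 2 `Cc1cc(N2CCCCC2)nc2ccc(NC(=O)c3ccc(Cl)c(Cl)c3)cc12` gives 31100 nM and compound 3 `Cc1cc(N2CCCC2)nc2ccc(NC(=O)c3ccc(Cl)c(Cl)c3)cc12` gives 26300 nM, the two differing only by a 1.2-fold lower number from compound 2 to compound 3 (0.07 log units; within the scatter). Compound 1 thus stands lowest of the three numbers, its separation from compound 3 and from compound 2 lying beyond the scatter.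

Compound 4 `CCN1CCN(c2cc(C)c3cc(NC(=O)c4ccc(Br)cc4)ccc3n2)CC1` differs from compound 1 by bromo in place of chloro on an aromatic carbon. Within the data shown here, no measured step bears on this change: the one step on record concerns the amine ring of the shared core, not the 4-chlorophenyl. With nothing to point either way, the step of a 1.0-fold lower number from compound 1 to compound 4 (0.01 log units; within the scatter) is expected to stay within the scatter. Compound 4 is estimated at 1500 nM, with a range from 700 nM to 3500 nM.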

Compound 4, half-maximal inhibitory concentration: 5940 nM
Compound 4: middle estimate off by 4.0-fold (0.60 log units), on the low side, and the stated range ends below it.
By their numbers in this assay, from the lowest: compound 1; then compound 4; then compounds 3 and 2 (each within the scatter of the next).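

The position on the phenyl ring is sensitive to the identity of the halogen: in this assay, bromo in place of chloro gives a 3.9-fold higher number from compound 1 to compound 4 (0.59 log units; beyond the scatter) on the shared core. Among these compounds, the earlier step concerned only the amine ring, so this is the only reading at this position, para to a large group. Nothing on hand accounts for the step.

Open, on these data alone, is how fluoro, methoxy or nitrile would read in the same place. Also open, as far as these compounds go, is whether the bromo step carries over to cores bearing piperidin-1-yl or pyrrolidin-1-yl.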